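Notes on the anilino-urea series: compound 1 toward compound 4

A few compounds are considered here, and "the series" means these few. Any claim that something is new, unique, unknown or untested is made for them only; others in the source may bear on it.

The shared core of this series is seen in compound 1 `CCc1ccc(Nc2cc(NC(=O)Nc3c(Cl)cccc3Cl)ncn2)cc1`, which in a functional assay on NCI-H226 cells (Homo sapiens) for inhibition, read by MTT assay, with a stated time of 48 h, tested at 10 uM (on this read-out higher numbers stand for more inhibition at the one concentration tested (going by the name of the read-out) and lower numbers for less inhibition), gives 39.5%. Two further members are measured in the same way. Compound 2 `COc1ccc(C(F)(F)F)cc1Nc1cc(NC(=O)Nc2c(Cl)cccc2Cl)ncn1` gives 60.1%, and compound 3 `CC(C)(C)c1ccc(Nc2cc(NC(=O)Nc3c(Cl)cccc3Cl)ncn2)cc1` gives 40%. Compound 1 holds the lowest of the three numbers; its nearest neighbour is compound 3, its furthest is compound 2, whose value stands beyond the scatter above it.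

Within the data shown here, the one single-point step among the measured compounds, a number 0.5 percentage points higher from compound 1 to compound 3 (within the scatter), stays within the scatter, so a larger alkyl chain on the aromatic carbon changes little here.

Compound 4 `COc1ccc(Nc2cc(NC(=O)Nc3c(Cl)cccc3Cl)ncn2)cc1C` is not yet measured. Relative to compound 1 it carries 4-methoxy-3-methylphenyl in place of 4-ethylphenyl on a nitrogen on an aromatic ring. Among the measured compounds shown here, no measured step covers this exchange. The step from compound 1 to compound 3 bears on it only insofar as it shows that a change on the aryl ring need not move the read-out. Compound 2, which also bears a methoxy group on its aryl ring, sits higher than compound 1, but that pair differs in more than one place, so only the two values themselves can be noted.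

Compound 4 is therefore expected to give 47% in this assay, a step of a number 7.5 percentage points higher from compound 1 to compound 4 (within the scatter), with a range from 32% to 63%.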

Compound 4, a percentage reported as inhibition, at one concentration (the size of the read-out at that concentration, not a potency): 50%
Beside the measured number, compound 4's estimate is 3 percentage points below it, within the range that was stated.
By their numbers in this assay, from the lowest: compounds 1, 3 and 4 (each within the scatter of the next, the first and the last beyond it); then compound 2.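

On a nitrogen on an aromatic ring, 4-methoxy-3-methylphenyl in place of 4-ethylphenyl gives a number 10.5 percentage points higher from compound 1 to compound 4 (beyond the scatter) in this assay and so shows that an exchange at this position can move the read-out modestly beyond the scatter, which a number 0.5 percentage points higher from compound 1 to compound 3 (within the scatter) did not show for tert-butyl in place of ethyl. Among these compounds, the exchange replaces the single ethyl group with two groups on the ring, a methoxy and a methyl, and the entering group carries one hydrogen-bond acceptor where the leaving group has none, so the step belongs to the whole 4-methoxy-3-methylphenyl group and cannot be divided between its parts. Nothing available here bears on the reason for this step.

The compounds shown leave open how far the methoxy group alone or the methyl group alone would account for the step, which a 4-methoxyphenyl or a 3-methylphenyl group on the same nitrogen would address. They also leave open what a longer alkoxy chain such as ethoxy, or an amine or a carboxylic acid on the aryl ring, would give in this assay at this position.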